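A few compounds are considered here, and "the series" means these few. Any claim that something is new, unique, unknown or untested is made for them only; others in the source may bear on it.

Measured in a functional assay on U-87MG ATCC cells (Homo sapiens) for cytotoxicity, read by MTT assay, with a stated time of 72 h; on this read-out higher numbers stand for weaker inhibition and lower numbers for stronger inhibition:
compound 1 `CN(C)CCn1cnnc1-c1cc(Oc2ccc(NC(=O)N/N=C/c3cccc(Br)c3)cc2F)ccn1` gives 830 nM;
compound 3 `CN(C)CCn1cnnc1-c1cc(Oc2ccc(NC(=O)N/N=C/c3ccccc3O[N+](=O)[O-])cc2F)ccn1` gives 7150 nM;
compound 2 `CN(C)CCn1cnnc1-c1cc(Oc2ccc(NC(=O)N/N=C/c3ccc(O)c(F)c3)cc2F)ccn1` reaches only the assay limit, > 100000 nM.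

Compound 1 holds the lowest of the two numbers in this assay, with compound 3 nearest at an 8.6-fold higher number from compound 1 to compound 3 (0.94 log units; beyond the scatter). Compound 4 `COc1cc(/C=N/NC(=O)Nc2ccc(Oc3ccnc(-c4nncn4CCN(C)C)c3)c(F)c2)ccc1O` differs from compound 1 by 4-hydroxy-3-methoxyphenyl in place of 3-bromophenyl on a carbon with a double bond to nitrogen. Going by the values given here, two measured steps bear on this change: the modest one an 8.6-fold higher number from compound 1 to compound 3 (0.94 log units; beyond the scatter), and the large one an at least 120-fold higher number from compound 1 to compound 2 (2.08 log units; beyond the scatter), which ends at a limit (the limit of > 100000 nM in this assay, at which 1 of the 3 values shown sits). The incoming 4-hydroxy-3-methoxyphenyl shares its hydroxy with the 3-fluoro-4-hydroxyphenyl of compound 2, so a large increase is expected in this assay. Compound 4 is therefore estimated at 30000 nM, within 5000 nM to 150000 nM. That estimate means an expected step of a 36-fold higher number from compound 1 to compound 4 (1.56 log units; beyond the scatter).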

Compound 4, half-maximal inhibitory concentration: > 100000 nM
Compound 4 gave a limit, no number (the forecaster's own chance of this, stated with the estimate: 35%); middle value at least 3.3-fold (0.52 log units) from the limit.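

In this assay, a second group carrying a hydroxy at this carbon with a double bond to nitrogen also ends at the assay limit, giving an at least 120-fold higher number from compound 1 to compound 4 (2.08 log units; beyond the scatter) and an at least 13-fold higher number from compound 3 to compound 4 (1.14 log units; beyond the scatter). Among the four compounds, both groups with a hydroxy sit at the limit, while 3-bromophenyl and 2-(nitrooxy)phenyl give numbers, so the rise is not confined to the fluoro-bearing group of compound 2. The step from compound 2 to compound 4 cannot be read because both end at the limit: the limit of > 100000 nM in this assay, at which 2 of the 4 values shown sit.

As far as these compounds go, it remains open whether the hydroxy itself goes with these higher numbers. From the compounds shown here alone, how a phenyl bearing an amine or a carboxylic acid would read at this place also remains open.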